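Methyl for cyclohexylcarbonyl on the ring amine

The source may hold more compounds than are shown below. What is called first, only, known or untested is meant among the compounds shown, and "the series" means these compounds.

In a physicochemical assay for lipophilicity, read by HPLC, measured as chromatographic lipophilicity, at pH 7.4 (on this read-out lower numbers stand for lower lipophilicity and higher numbers for higher lipophilicity), compound 2 `O=C(C1CCCCC1)N1CCC(C(=O)N2N=CCC2c2ccccc2)CC1` holds the higher of the two numbers at 5.4, while compound 1 `CCC(=O)N1CCC(C(=O)N2N=CCC2c2ccccc2)CC1` gives 3.2. Compound 3 `CN1CCC(C(=O)N2N=CCC2c2ccccc2)CC1` has methyl in place of cyclohexylcarbonyl on an amine nitrogen in a ring. Going by the values given here, one measured step bears on this, the large a number 2.20 log units higher from compound 1 to compound 2 (beyond the scatter) for cyclohexyl in place of ethyl on a carbonyl carbon. Among the compounds with values here, no measured compound shows the change on the nitrogen itself. A large fall in this assay is therefore expected, greater than that step. The estimated step is a number 3.40 log units lower from compound 2 to compound 3 (beyond the scatter), with wide uncertainty. For compound 3 the estimated value is 2, within an expected range of 1.2 to 2.9 for now.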

Compound 3, distribution coefficient: 1.1
Beside the measured number, compound 3's estimate is 0.90 log units above it; the whole stated range lies above it.
By their numbers in this assay, from the lowest: compound 3; then compound 1; then compound 2.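

In this assay there is a number 4.30 log units lower from compound 2 to compound 3 (beyond the scatter) and a number 2.10 log units lower from compound 1 to compound 3 (beyond the scatter) when methyl stands on the amine nitrogen in a ring. The earlier step covered only the group on the carbonyl carbon, whereas these steps show large falls when cyclohexylcarbonyl or propanoyl on the nitrogen gives way to methyl. Nothing measured here accounts for the size of these falls.

Open, from the compounds shown here alone, is how a longer chain on that nitrogen would read against compound 3. Going by these compounds, the reading with a carboxylic acid carried on that nitrogen also remains open.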